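The source may report more compounds than this note shows. Statements on the series, on what has been measured and on what is new or still open speak of the compounds shown alone.

Of the compounds shown here, three have been measured in a functional assay on SW-620 cells (Homo sapiens) for antiproliferative activity, read by MTT assay, with a stated time of 72 h; on this read-out lower numbers stand for stronger inhibition and higher numbers for weaker inhibition. Compound 1 `O=c1nc2oc(C3CC3)c(C#CC3CC3)c2cn1Cc1cn(Cc2ccccc2)nn1` gives 9720 nM, the lowest of the three numbers. Compound 3 `O=c1nc2oc(C3CC3)cc2cn1Cc1cn(Cc2ccccc2)nn1` gives 54700 nM, and compound 2 `O=c1nc2oc(CCCCl)c(C#CCCCCCl)c2cn1Cc1cn(-c2ccc(F)cc2)nn1`, which carries other groups at several places on the shared core, gives 69600 nM. Among the compounds with values here, the only single-point step measured so far is a 5.6-fold higher number from compound 1 to compound 3 (0.75 log units; beyond the scatter), and it concerns the 2-cyclopropylethynyl group, not the group on the ring nitrogen. Compound 4 `O=c1nc2oc(C3CC3)c(C#CC3CC3)c2cn1Cc1cn(-c2ccc(Cl)cc2)nn1` has not yet been measured. It differs from compound 1 by 4-chlorophenyl in place of benzyl on an aromatic nitrogen. Within the data shown here, no measured pair changes only this position, so neither the size nor the direction of this step can be read from the data; compound 2 shows a weaker number with other groups in place, but it differs at more than one point. In this assay compound 4 is therefore expected to sit near compound 1, with a wide range. The estimate for compound 4 is 12000 nM, expected to lie between 3000 nM and 50000 nM. This expectation corresponds to a 1.2-fold higher number from compound 1 to compound 4 (0.09 log units; within the scatter).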

Compound 4, half-maximal inhibitory concentration: 36900 nM
The estimate for compound 4 lay 3.1-fold (0.49 log units) below the measured number; measured number inside the range.
By their numbers in this assay, from the lowest: compound 1; then compounds 4, 3 and 2 (each within the scatter of the next).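

In this assay, putting 4-chlorophenyl in place of benzyl on the aromatic nitrogen gives a 3.8-fold higher number from compound 1 to compound 4 (0.58 log units; beyond the scatter) so this position affects the number while the rest of compound 1 stays fixed. Both groups have 7 heavy atoms and one six-membered aromatic ring of carbon only, so a swap that leaves those counts unchanged still moves the number beyond the scatter. Nothing measured here explains this shift.

From the compounds shown here alone, the step changes two things at once, removing the carbon link of benzyl and adding chlorine, so the share of each stays open; plain phenyl or 4-chlorobenzyl at this place would separate them. Also open, going by these compounds, is how an amine or a carboxylic acid on that aromatic ring would read, and whether the step holds with other groups on the shared core.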